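Working notes: the step from compound 2 to compound 3

A few compounds are considered here, and "the series" means these few. Any claim that something is new, unique, unknown or untested is made for them only; others in the source may bear on it.

Values so far in an ADME assay on HEK293 cells (Homo sapiens) for cytotoxicity, read by MTT assay, with a stated time of 24 h (a higher number here means a weaker inhibitor, a lower number a stronger inhibitor), are these
- compound 1 `CN(C)CCCNc1nc2cc([N+](=O)[O-])ccc2nc1NCc1ccc(F)cc1` gives 4.28 ug/mL
- compound 2 `CN(C)CCCNc1nc2cc([N+](=O)[O-])ccc2nc1NCc1cccc(Br)c1` gives 3.66 ug/mL

Compound 2 stands level with compound 1 within the scatter. The next compound, compound 3 `CN(C)CCCNc1nc2cc([N+](=O)[O-])ccc2nc1NCc1cc(F)cc(C(F)(F)F)c1`, brings 3-fluoro-5-(trifluoromethyl)phenyl in place of 3-bromophenyl on a saturated chain carbon bound to a nitrogen on an aromatic ring at the same place, on a saturated chain carbon bound to a nitrogen on an aromatic ring. Within the data shown here, the only measured step at this place is a 1.2-fold lower number from compound 1 to compound 2 (0.07 log units; within the scatter) and it is small. With one step to go on, no change beyond the scatter is expected in this assay here. The expected size is a 1.0-fold lower number from compound 2 to compound 3 (0.02 log units; within the scatter) by this estimate. For compound 3 the estimated value is 3.5 ug/mL with an expected range of 1.7 ug/mL to 7.2 ug/mL for now.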

Compound 3, half-maximal inhibitory concentration: 2.67 ug/mL
For compound 3 the middle estimate is 1.3-fold (0.12 log units) above the measured one, and the stated range covers the measured number.
By their numbers in this assay, from the lowest: compounds 3, 2 and 1 (each within the scatter of the next).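

In this assay, 3-fluoro-5-(trifluoromethyl)phenyl, with 11 heavy atoms against the 7 of 3-bromophenyl, is taken up at this place with a step inside the scatter (a 1.4-fold lower number from compound 2 to compound 3 (0.14 log units; within the scatter)). The wider comparison also stays inside the scatter (a 1.6-fold lower number from compound 1 to compound 3 (0.20 log units; within the scatter)), so the three substituted phenyl groups cannot be told apart here. No evidence on the cause accompanies this result.
On these data alone, whether an amine, a carboxylic acid or a longer chain on this saturated carbon would move the number beyond the scatter remains open.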